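The source may report more compounds than this note shows. Statements on the series, on what has been measured and on what is new or still open speak of the compounds shown alone.

In a functional assay on cells (Cancer cell lines, Homo sapiens) for inhibition, with a stated time of 48 h (a lower number here means a stronger inhibitor of growth, a higher number a weaker inhibitor of growth), three related compounds have been measured. Compound 1 `COc1cc2c(/C=C3/C(=O)Nc4cc(Cl)ccc43)c(Cl)[nH]c2cc1C` gives 230 nM, compound 2 `COc1cc2c(cc1C)N(C)C(=O)/C2=C/c1c(Cl)n(C)c2cc(C)c(OC)cc12` gives 15900 nM, and compound 3 `COc1cc2c(/C=C3/C(=O)N(C)c4ccccc43)c[nH]c2cc1C` gives 4170 nM. Compound 3 therefore sits in the middle, a weaker inhibitor of growth than compound 1 and a stronger one than compound 2, with both gaps beyond the usual scatter. Compound 4 `COc1cc2c(/C=C3/C(=O)N(C)c4ccc(O)cc43)c[nH]c2cc1C` differs from compound 3 in one place: hydroxy in place of hydrogen on an aromatic carbon. For the measured compounds named here, no measured pair differs in one place alone, so the data offer no direct guide to this change. A small move toward stronger inhibition is expected, possibly none beyond the scatter. The expected step is a 1.4-fold lower number from compound 3 to compound 4 (0.14 log units; within the scatter). For compound 4 the estimated value is 3000 nM, with a range of 800 nM to 11000 nM.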

Compound 4, concentration for 50% growth inhibition: 5890 nM
Estimate against measurement, compound 4: 2.0-fold (0.29 log units) below, and the stated range covers the measured number.
By their numbers in this assay, from the lowest: compound 1; then compounds 3 and 4 (each within the scatter of the next); then compound 2.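

Placing hydroxy on this aromatic carbon, in place of hydrogen, gives a 1.4-fold higher number from compound 3 to compound 4 (0.15 log units; within the scatter) in this assay. For the compounds shown here, this is the first one-place comparison, and it shows that adding this group at this position leaves growth inhibition indistinguishable from that of the compound without it. Nothing measured here speaks to the reason for this result.

The compounds shown leave open whether an amine or a carboxylic acid on this same carbon would also leave the number within the scatter. They also leave open whether hydroxy would have so small an effect on the core of compound 1.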